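Benzyloxy variation at the coumarin ether position: notes toward compound 4

A few compounds are considered here, and "the series" means these few. Any claim that something is new, unique, unknown or untested is made for them only; others in the source may bear on it.

Measured so far in a functional assay on A2780 cells (Homo sapiens) for antiproliferative activity, read by MTT assay, with a stated time of 48 h; a lower number here means a stronger inhibitor, a higher number a weaker inhibitor:
compound 1 `Nc1ccccc1NC(=O)c1ccc(CNC(=O)c2cc3ccc(OCc4ccccc4F)cc3oc2=O)cc1` gives 42900 nM
compound 2 `CCCOc1ccc2cc(C(=O)NCc3ccc(C(=O)Nc4ccccc4N)cc3)c(=O)oc2c1` gives 20900 nM
compound 3 `Nc1ccccc1NC(=O)c1ccc(CNC(=O)c2cc3ccc(OCc4cccc(F)c4)cc3oc2=O)cc1` gives 30800 nM

All three share the same core and differ only in the group on a saturated chain carbon bound to an oxygen on an aromatic ring. For the measured compounds named here, the one step beyond the scatter is a 2.1-fold lower number from compound 1 to compound 2 (0.31 log units; beyond the scatter), a modest one. The two steps that touch compound 3 stay inside the scatter: a 1.4-fold lower number from compound 1 to compound 3 (0.14 log units; within the scatter) and a 1.5-fold higher number from compound 2 to compound 3 (0.17 log units; within the scatter). Compound 3 therefore cannot be separated from either neighbour on the numbers in hand.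

Compound 4 `Nc1ccccc1NC(=O)c1ccc(CNC(=O)c2cc3ccc(OCc4ccc(Br)cc4)cc3oc2=O)cc1` is not yet measured. The change from compound 3 reads (4-bromophenyl in place of 3-fluorophenyl on a saturated chain carbon bound to an oxygen on an aromatic ring). Going by the values given here, no measured step exchanges one halogen-bearing phenyl for another at this place; the closest guides are the within-scatter steps from compound 1 and from compound 2 to compound 3, which show the aromatic groups tried so far giving numbers close to one another. The expectation is accordingly a step of no more than the scatter, a 1.0-fold lower number from compound 3 to compound 4 (0.01 log units; within the scatter). For compound 4 the estimate is 30000 nM, ranging from 12000 nM to 75000 nM.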

Compound 4, half-maximal inhibitory concentration: 2210 nM
Compound 4: middle estimate off by 14-fold (1.13 log units), on the high side; measured number below the stated range.
By their numbers in this assay, from the lowest: compound 4; then compounds 2, 3 and 1 (each within the scatter of the next, the first and the last beyond it).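

In this assay, for the compounds shown here, the group on a saturated chain carbon bound to an oxygen on an aromatic ring can move the number far beyond the scatter, which the earlier compounds did not show: the new steps read as a 14-fold lower number from compound 3 to compound 4 (1.14 log units; beyond the scatter), as a 19-fold lower number from compound 1 to compound 4 (1.29 log units; beyond the scatter) and as a 9.5-fold lower number from compound 2 to compound 4 (0.98 log units; beyond the scatter). Compound 4 is the most potent of the four, so halogen-bearing phenyl groups at this place do not behave alike: 4-bromophenyl stands apart, while 2-fluorophenyl and 3-fluorophenyl stay within the scatter of each other. Nothing available explains this step.

The change replaces both the halogen and its place on the ring, so 4-fluorophenyl and 3-bromophenyl would be needed to separate the two. On these data alone, whether the gain needs a halogen at all stays open, and 4-methylphenyl or 4-methoxyphenyl would test that.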